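Methoxy to Nitro on the Aryl Ring

The source may report more compounds than this note shows. Statements on the series, on what has been measured and on what is new or still open speak of the compounds shown alone.

Within the data shown here, compound 2 `C=C(C)[C@@H]1CC=C(C)/C(=N/NC(=O)Nc2nnc(-c3ccc(OC)cc3)o2)C1` is one of two compounds tested so far in a functional assay on the whole organism (strain Swiss albino) with Mus musculus as the target, with a stated time of 4 h (a higher number here means that more compound is needed for the effect, a lower number that less compound is needed), where compound 2 gives 300 mg/kg. Among the measured compounds shown here, its only measured neighbour is compound 1 `C=C(C)[C@@H]1CC=C(C)/C(=N/NC(=O)Nc2nnc(-c3ccc(Cl)cc3)o2)C1`, which in this assay gives 300 mg/kg. The step of no change at the digits printed from compound 1 to compound 2 (within the scatter) came with methoxy in place of chloro on an aromatic carbon and left the dose unchanged. Compound 3 `C=C(C)[C@@H]1CC=C(C)/C(=N/NC(=O)Nc2nnc(-c3ccc([N+](=O)[O-])cc3)o2)C1` now differs from compound 2 by nitro in place of methoxy on an aromatic carbon. For the measured compounds named here, that single earlier step is the only guide for this change, and since it lay within the scatter, the expectation is that compound 3 also moves little in this assay, an estimated step of no change at the digits printed from compound 2 to compound 3 (within the scatter) with no direction beyond the scatter. Compound 3 is therefore estimated at 300 mg/kg, with a range from 150 mg/kg to 600 mg/kg.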

Compound 3, minimum effective dose: 300 mg/kg
Compound 3: middle estimate and measured number agree at the digits printed; measured number inside the range.
By their numbers in this assay, from the lowest: compounds 1, 2 and 3 (each within the scatter of the next).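

In this assay, among these compounds, the earlier pair showed only one swap on this aromatic carbon, and compound 3 adds a third group at the same place: no change at the digits printed from compound 2 to compound 3 (within the scatter) and no change at the digits printed from compound 1 to compound 3 (within the scatter). Among these three compounds, then, the minimum effective dose does not respond to which of chloro, methoxy or nitro sits on the ring, so the flat result no longer rests on a single comparison. No measurement available here explains this lack of response.

As far as these compounds go, whether the dose would stay level with a quite different group at this place, such as an amine or a carboxylic acid, remains open. Also open, from the compounds shown here alone, is whether a change elsewhere in the shared core would move the dose at all.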